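A few compounds are considered here, and "the series" means these few. Any claim that something is new, unique, unknown or untested is made for them only; others in the source may bear on it.

Compound 2 `C[C@@H]1CN(C(=O)c2nc(Nc3cc(C4CC4)[nH]n3)c3cc(Cl)ccc3n2)CCN1C(=O)OCOC(=O)C(C)(C)C` is the acyloxymethyl analogue of compound 1 `C[C@@H]1CN(C(=O)c2nc(Nc3cc(C4CC4)[nH]n3)c3cc(Cl)ccc3n2)CCN1C(=O)OC(C)(C)C`. Among the compounds with values here, in a physicochemical assay, read by HPLC, in phosphate buffer, with a stated time of 2 h, at pH 7.4 (on this read-out higher numbers stand for a more stable compound and lower numbers for a less stable compound), compound 1 gives 99.1%, and in the same test compound 2 gives 97.7%, so that the one measured step, a number 1.4 percentage points lower from compound 1 to compound 2 (within the scatter), stays within the scatter. Within the data shown here, compound 2 thus stands on the lower of the two numbers known, with compound 1 its only neighbour and close to it.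

Compound 3 `CC(OC(=O)N1CCN(C(=O)c2nc(Nc3cc(C4CC4)[nH]n3)c3cc(Cl)ccc3n2)C[C@H]1C)OC(=O)C(C)(C)C` is compound 2 with one further change: methyl in place of hydrogen on a saturated chain carbon bound to two oxygens next to a carbonyl group. Among the measured compounds shown here, no measured step touches this carbon, so the only guide is that the exchange of tert-butyl for (((tert-butyl)carbonyl)oxy)methyl on the oxygen next to the carbonyl group left the read-out essentially unmoved. Given that compound 2 gives 97.7%, the step to compound 3 is expected to be small and, as a number 1.7 percentage points lower from compound 2 to compound 3 (within the scatter), to stay within the scatter. Compound 3 is therefore estimated to give 96% in this assay, with a range from 88% to 100%.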

Compound 3, percent of the compound remaining: 90.5%
Beside the measured number, compound 3's estimate is 5.5 percentage points above it; measured number inside the range.
By their numbers in this assay, from the lowest: compounds 3, 2 and 1 (each within the scatter of the next).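

In this assay, within the data shown here, methyl in place of hydrogen on a saturated chain carbon bound to two oxygens gives a number 7.2 percentage points lower from compound 2 to compound 3 (within the scatter), the first reading at this carbon; in size this step exceeds the earlier a number 1.4 percentage points lower from compound 1 to compound 2 (within the scatter), though both remain within the scatter. Measured from the tert-butyl compound, the whole exchange to 1-(((tert-butyl)carbonyl)oxy)ethyl gives a number 8.6 percentage points lower from compound 1 to compound 3 (within the scatter), so even this larger replacement on the oxygen next to the carbonyl group produces no step beyond the scatter on this read-out. Nothing in the information shown gives a reason for the size of either step.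

The compounds shown leave open whether an ethyl group or a second methyl on that same carbon would produce a step beyond the scatter. They also leave open how the read-out would respond if an amine or a carboxylic acid replaced the tert-butyl end of the 1-(((tert-butyl)carbonyl)oxy)ethyl group.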